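Swapping the nitro-bearing ring for a bromo trifluoromethyl ring

The compounds below may be only part of what the source reports. "The series", "measured", "known", "first", "only" and "open" are said of these compounds alone.

Going by the values given here, compound 1 `O=C(Nc1ccc(Oc2ccc(-c3nccs3)cc2)cc1)Nc1ccc(Cl)c([N+](=O)[O-])c1` is one of two compounds measured in a functional assay on A549 cells (Homo sapiens) for inhibition, read by MTT assay and WST assay, with a stated time of 72 h (on this read-out lower numbers stand for stronger inhibition and higher numbers for weaker inhibition), where compound 1 gives 3890 nM. Among the compounds with values here, its only measured neighbour, compound 2 `O=C(Nc1ccc(Oc2ccc(-c3nccs3)cc2)cc1)Nc1cc(C(F)(F)F)ccc1Cl`, gives 7040 nM in this assay; the step of a 1.8-fold higher number from compound 1 to compound 2 (0.26 log units; within the scatter) leaves the two compounds level, so compound 1 stands alongside compound 2 rather than apart from it. Compound 3 `O=C(Nc1ccc(Oc2ccc(-c3nccs3)cc2)cc1)Nc1cc(Br)cc(C(F)(F)F)c1` has not yet been measured. It differs from compound 1 by 3-bromo-5-(trifluoromethyl)phenyl in place of 4-chloro-3-nitrophenyl on an amide-type nitrogen. Within the data shown here, the one measured step that bears on this change, a 1.8-fold higher number from compound 1 to compound 2 (0.26 log units; within the scatter), also exchanges the 4-chloro-3-nitrophenyl for a ring carrying a halogen and a trifluoromethyl group, and that step stayed within the scatter. The expectation for compound 3 in this assay is therefore a step of a 1.3-fold higher number from compound 1 to compound 3 (0.11 log units; within the scatter), not beyond the scatter. Compound 3 is thus estimated at 5000 nM, with a range from 2000 nM to 13000 nM.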

Compound 3, half-maximal inhibitory concentration: 2710 nM
Beside the measured number, compound 3's estimate is 1.8-fold (0.27 log units) above it; measured number inside the range.
By their numbers in this assay, from the lowest: compounds 3, 1 and 2 (each within the scatter of the next, the first and the last beyond it).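

In this assay, the step of a 1.4-fold lower number from compound 1 to compound 3 (0.16 log units; within the scatter) shows that the 3-bromo-5-(trifluoromethyl)phenyl on the amide-type nitrogen keeps compound 3 level with compound 1, even though the 4-chloro-3-nitrophenyl and its nitro group are gone. Going by these compounds alone, the step of a 2.6-fold lower number from compound 2 to compound 3 (0.41 log units; beyond the scatter) is the first at this position to lie beyond the scatter, though only modestly, so the number here responds even when one halogen- and trifluoromethyl-bearing ring replaces another. No measurement shown accounts for this difference.

The 2-chloro-5-(trifluoromethyl)phenyl and 3-bromo-5-(trifluoromethyl)phenyl rings differ in both the halogen and its printed location, so the compounds shown cannot separate these two changes. They also leave open how this position would respond to a ring bearing an amine or a carboxylic acid.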